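The source may hold more compounds than are shown below. What is called first, only, known or untested is meant among the compounds shown, and "the series" means these compounds.

Working notes on the series. Compound 1 `Nc1nc(Cl)c2nnn([C@H]3CCCC[C@H]3CO)c2n1` and compound 2 `Nc1nc(N)c2nnn([C@H]3CCCC[C@H]3CO)c2n1` share one core; compound 3 `CC1(C)C(CO)CC1Cn1cnc2c(N)nc(N)nc21` and the unmeasured compound 4 `CC1(C)C(CO)CC1Cn1cnc2c(Cl)nc(N)nc21` share another, and the difference between the two cores is not broken down here. In an ADME assay on L1210/0 cells (Mus musculus) for cytotoxicity, with a stated time of 48 h (a lower number here means a stronger inhibitor, a higher number a weaker inhibitor), compound 1 gives 95500 nM. Compound 2 reaches the limit of the assay in this assay, reported as > 200000 nM. Compound 3 likewise reaches the limit in this assay, reported as > 200000 nM. The change from compound 2 to compound 1 is chloro in place of amino on an aromatic carbon and its step is an at least 2.0-fold lower number from compound 2 to compound 1 (0.32 log units; beyond the scatter). The change from compound 3 to compound 4 is chloro in place of amino on an aromatic carbon; the place reads the same word for word, so this is the same change made a second time, occurring twice among the compounds shown. Because two of the three values sit at the limit of > 200000 nM in this assay, at which 2 of the 3 values shown sit, the earlier step is known only as a bound, not a size. For compound 4 the expected step in this assay is an at least 1.3-fold lower number from compound 3 to compound 4 (0.12 log units; that floor lies within the scatter), resting on an at least 2.0-fold lower number from compound 2 to compound 1 (0.32 log units; beyond the scatter). Compound 4 is estimated at 150000 nM, between 60000 nM and 400000 nM.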

Compound 4, half-maximal inhibitory concentration: > 200000 nM
Compound 4 was reported as a limit; the forecaster's own chance of this, stated with the estimate: 45%; at least 1.3-fold (0.12 log units) between middle value and limit.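

In this assay compound 4 gives > 200000 nM, which is a limit and not a number. No new step from compound 3 to compound 4 can be read, because both compounds sit at a limit: the limit of > 200000 nM in this assay, at which 3 of the 4 values shown sit.

The compounds shown leave open whether chloro in place of amino on an aromatic carbon changes the number at all on the core of compound 3.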